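A few compounds are considered here, and "the series" means these few. Any claim that something is new, unique, unknown or untested is made for them only; others in the source may bear on it.

Among the measured compounds shown here, compound 3 `CCC1(OC(=O)N2CC3COCC(C2)C3Oc2ncnc(Nc3ccc(C#N)cc3F)c2F)CC1` gives 6 nM in a functional assay on HEK293 cells for agonist activity at Glucose-dependent insulinotropic receptor (Homo sapiens), read by cAMP accumulation, with a stated time of 30 min (on this read-out higher numbers stand for an effect only at larger amounts of compound and lower numbers for an effect already at smaller amounts), the lowest of the three numbers measured so far. Compound 1 `CC1(OC(=O)N2CC3COCC(C2)C3Oc2ncnc(Nc3ccc(F)cc3F)c2F)CC1` gives 15 nM and compound 2 `CC1(OC(=O)N2CC3COCC(C2)C3Oc2ncnc(Nc3ccc(-n4cncn4)cc3F)c2F)CC1` gives 19 nM; both of these stand beyond the scatter from compound 3, compound 2 the further of the two. For the measured compounds named here, the only measured step between neighbours, a 1.3-fold higher number from compound 1 to compound 2 (0.10 log units; within the scatter), concerns the substituent on the aniline ring and lies within the scatter.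

Compound 4 `COCC1(OC(=O)N2CC3COCC(C2)C3Oc2ncnc(Nc3ccc(C#N)cc3F)c2F)CC1` differs from compound 3 by methoxy in place of methyl on a saturated chain carbon bound to a saturated ring carbon. Going by the values given here, no measured step touches this part of the series: the one step available, from compound 1 to compound 2, sits on the aniline side, and the three compounds differ among themselves at the ring and at the chain on the cyclopropane, so the change from methyl to methoxy is not covered. On that basis no step beyond the scatter is expected, and the estimate for compound 4 in this assay is 8 nM, with a range of 3 nM to 22 nM, corresponding to an expected step of a 1.3-fold higher number from compound 3 to compound 4 (0.12 log units; within the scatter).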

Compound 4, half-maximal effective concentration: 49 nM
The estimate for compound 4 lay 6.1-fold (0.79 log units) below the measured number; measured number outside the range, above it.
By their numbers in this assay, from the lowest: compound 3; then compounds 1 and 2 (each within the scatter of the next); then compound 4.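

In this assay, among the compounds shown here, methoxy in place of methyl on a saturated chain carbon bound to a saturated ring carbon gives an 8.2-fold higher number from compound 3 to compound 4 (0.91 log units; beyond the scatter), so this position responds to a small change, which the earlier compounds could not show. For the compounds shown here, the only earlier step, a 1.3-fold higher number from compound 1 to compound 2 (0.10 log units; within the scatter), lies within the scatter and concerns a different part of the series. Nothing available explains why the change from 1-ethylcyclopropyl to 1-(methoxymethyl)cyclopropyl raises the number.

The compounds shown do not separate the effect of the oxygen from that of the longer chain, which an all-carbon propyl group at this place could address, while a hydroxymethyl group or an amine would extend the comparison. Going by these compounds, it also remains open whether the same step appears with fluoro or 1H-1,2,4-triazol-1-yl in place of the nitrile.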